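The source may hold more compounds than are shown below. What is called first, only, known or untested is meant among the compounds shown, and "the series" means these compounds.

In a functional assay on MCF7 cells (Homo sapiens) for inhibition, read by MTT assay, with a stated time of 24 h (on this read-out lower numbers stand for stronger inhibition and higher numbers for weaker inhibition), compound 1, whose structure is `O=C(O)C1=Cc2ccccc2OC1(OCc1cc(-c2ccc(F)cc2)no1)C(F)(F)F`, gives 64200 nM. This is the highest of the two numbers measured here; the nearest is compound 3, with structure `CCOC(=O)C1=Cc2ccccc2OC1(OCc1cn(CC(=O)Nc2ccccc2F)nn1)C(F)(F)F`, which in this assay gives 42100 nM, a gap that stays within the scatter of repeated measurements, so the two cannot be ranked. Compound 2, with structure `CCOC(=O)C1=Cc2ccccc2OC1(OCc1cc(-c2ccc(OC)cc2)no1)C(F)(F)F`, shows only a limit in this assay: > 150000 nM, as stated in the limit of > 150000 nM in this assay, at which 1 of the 3 values shown sits.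

The next compound, compound 4, has structure `O=C(O)C1=Cc2ccccc2OC1(OCc1cc(-c2ccc3ccccc3c2)no1)C(F)(F)F`. It differs from compound 1 in one place: naphthalen-2-yl in place of 4-fluorophenyl on an aromatic carbon. Among the measured compounds shown here, no pair of measured compounds here differs in a single place, so there is no measured step to lean on. The three compounds share a core and spread only within a narrow band, and the change is a swap of one aromatic group for a larger one. The step expected in this assay is a 1.4-fold lower number from compound 1 to compound 4 (0.15 log units; within the scatter), which is not beyond the scatter. Compound 4 is therefore estimated at 45000 nM, with a range from 12000 nM to 150000 nM.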

Compound 4, half-maximal inhibitory concentration: > 150000 nM
Compound 4 gave a limit, no number; the forecaster's own chance of this, stated with the estimate: 25%; middle value at least 3.3-fold (0.52 log units) from the limit.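

Among the compounds shown here, this is the first step between compounds that differ in one place, and it falls on the five-membered aromatic ring, next to the ring nitrogen: naphthalen-2-yl in place of 4-fluorophenyl gives an at least 2.3-fold higher number from compound 1 to compound 4 (0.36 log units; beyond the scatter) in this assay. At this position, then, the change of aromatic group is not neutral, and the read-out moves towards weaker inhibition. Compound 4 gives a limit and not a number, so the step has a lower bound but no known full size: the limit of > 150000 nM in this assay, at which 2 of the 4 values shown sit.

The compounds shown leave open whether the shift follows from the second aromatic ring or from the departure of the fluorine, a question that plain phenyl at this position could separate. They also leave open whether an amine in place of the fluorine would give a lower number than compound 1.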